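Swapping the Aryl Group on the Amide Nitrogen

The source may hold more compounds than are shown below. What is called first, only, known or untested is meant among the compounds shown, and "the series" means these compounds.

Compound 1 `COc1ccc(-c2nc3c(C(=O)Nc4ccccc4F)cccc3[nH]2)cc1OC` gives 24.5 uM in an ADME assay on Vero cells (Chlorocebus sabaeus) for cytotoxicity; a higher number here means that more compound is tolerated, a lower number that less compound is tolerated.
Compound 2 `COc1ccc(-c2nc3c(C(=O)Nc4cnc(Cl)cn4)cccc3[nH]2)cc1OC` gives 78.3 uM in this assay.
Compound 3 `COc1ccc(-c2nc3c(C(=O)Nc4cnc(Cl)cn4)cccc3[nH]2)c(OC)c1OC` gives 65.2 uM in this assay.

Compound 2 holds the highest number of the three. Compound 3 sits close to it: the step from compound 2 to compound 3 was a 1.2-fold lower number from compound 2 to compound 3 (0.08 log units; within the scatter). Compound 1 lies further off: the step from compound 1 to compound 2 was a 3.2-fold higher number from compound 1 to compound 2 (0.50 log units; beyond the scatter).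

Compound 4 `COc1ccc(-c2nc3c(C(=O)Nc4nc(C#N)c(C#N)[nH]4)cccc3[nH]2)cc1OC` has not yet been measured in this assay. It differs from compound 2 in one place: 4,5-dicyano-1H-imidazol-2-yl in place of 5-chloropyrazin-2-yl on an amide-type nitrogen. Going by the values given here, of the measured steps, only the one from compound 1 to compound 2 touches the same position, exchanging one aromatic ring for another on the amide nitrogen, and it gave a modest rise. The step from compound 2 to compound 3 concerns a different part of the molecule. Among the compounds with values here, no measured step replaces a six-membered ring by a five-membered one, so the direction is uncertain, and the expectation for compound 4 is a step of about a 1.2-fold lower number from compound 2 to compound 4 (0.08 log units; within the scatter), within the scatter. Compound 4 is therefore estimated at 65 uM, expected between 25 uM and 160 uM.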

Compound 4, half-maximal toxic concentration: 43.1 uM
Beside the measured number, compound 4's estimate is 1.5-fold (0.18 log units) above it, and the stated range covers the measured number.
By their numbers in this assay, from the lowest: compounds 1, 4, 3 and 2 (each within the scatter of the next, the first and the last beyond it).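

On the amide nitrogen, a five-membered ring now stands where only six-membered rings stood before. In this assay, the change from 5-chloropyrazin-2-yl to 4,5-dicyano-1H-imidazol-2-yl gives a 1.8-fold lower number from compound 2 to compound 4 (0.26 log units; within the scatter), and the change from 2-fluorophenyl gives a 1.8-fold higher number from compound 1 to compound 4 (0.25 log units; within the scatter). Compound 4 thus cannot be told apart from either neighbour, although those two differ from each other by more than the scatter, and nothing shown here offers an explanation for this.

Compound 4 changes the ring size and adds two nitrile groups in a single step, so the compounds shown cannot separate the contribution of each. Going by these compounds, how a plain imidazol-2-yl ring without nitrile groups, or a carboxylic acid on the five-membered ring, would fare in this assay remains open.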